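The compounds below may be only part of what the source reports. "The series", "measured", "known", "first", "only" and "open" are said of these compounds alone.

Measured so far:
compound 1, `CCOc1ccc(Cl)cc1C(C)NC(=O)N(C)S(=O)(=O)c1ccccc1`, gives 10500 nM
compound 2, `CCOc1ccc(Cl)cc1C(C)NC(=O)NS(=O)(=O)c1ccc(Cl)cc1`, gives 281000 nM
compound 3, `CCOc1ccc(Br)cc1C(C)NC(=O)NS(=O)(=O)c1ccccc1`, gives > 300000 nM

All three were tested in a functional assay on thoracic aorta (Rattus norvegicus, strain Wistar), with a stated time of 15 min; a lower number here means that less compound is needed, a higher number that more compound is needed for the effect. Compound 3 stands at the edge of what this assay can report: its figure of > 300000 nM is a limit of the assay rather than a measured number, as noted by the limit of > 300000 nM in this assay, at which 1 of the 3 values shown sits. Compound 2, which carries a chloro on the sulfonyl-bearing ring, gives a numbered value of 281000 nM, close to that edge. Compound 1, which carries a methyl on the sulfonyl nitrogen, gives the lowest number, 10500 nM.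

The unmeasured compound 4, `CCOc1ccc(Cl)cc1C(C)NC(=O)NS(=O)(=O)c1ccccc1`, differs from compound 3 in one place: chloro in place of bromo on an aromatic carbon. With compound 2 giving 281000 nM, compound 4 is expected to stay near the top of the range. The expected step of an at least 1.2-fold lower number from compound 3 to compound 4 (0.07 log units; that floor lies within the scatter) is expected to be small, not beyond the scatter, though a step from a limit cannot be pinned down. Compound 4 is estimated at 250000 nM, with a range from 60000 nM to 1000000 nM.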

Compound 4, half-maximal effective concentration: > 300000 nM
Compound 4 ended at the assay's limit; the forecaster's own chance of this, stated with the estimate: 45%; middle value at least 1.2-fold (0.07 log units) away from the limit.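

Both compound 3 and compound 4 sit at a limit of this assay, so with bromo or chloro on the aromatic carbon para to the ethoxy group, the step between them cannot be read, because neither value is a true number: the limit of > 300000 nM in this assay, at which 2 of the 4 values shown sit. Hydrogen in place of chloro on an aromatic carbon gives an at least 1.0-fold higher number from compound 2 to compound 4 (0.02 log units; that floor lies within the scatter), so this change shows no effect that can be told from the scatter. Hydrogen in place of methyl on the amide-type nitrogen gives an at least 28-fold higher number from compound 1 to compound 4 (1.45 log units; beyond the scatter), which means the methyl of compound 1 goes with far less compound being needed.

Going by these compounds, it remains open whether fluoro or a methoxy group on that aromatic carbon would give a readable number rather than a limit. On these data alone, it is also open whether a longer chain such as ethyl on the amide-type nitrogen would match or pass methyl.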